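A few compounds are considered here, and "the series" means these few. Any claim that something is new, unique, unknown or untested is made for them only; others in the source may bear on it.

In a functional assay on HCT-15 cells (Homo sapiens) for cytotoxicity, read by CCK-8 assay and cell counting, with a stated time of 72 h (a lower number here means a stronger inhibitor, a higher number a weaker inhibitor), compound 2 `COc1ccc(-c2cc3cc(C)ccc3c(-c3cccc(O)c3)n2)cc1OC` gives 370 nM, the only plain number shown here. Compound 1 `COc1ccc(-c2cc3ccccc3c(-c3ccc(O)cc3)n2)cc1` reaches only the limit of > 50000 nM in this assay, a limit rather than a measured number, and it differs from compound 2 in more than one place, so the pair is reported without further comparison. Compound 3 `COc1ccc(-c2nc(-c3ccc(OC)c(OC)c3)cc3cc(C)ccc23)cc1` differs from compound 2 by one change: 4-methoxyphenyl in place of 3-hydroxyphenyl on an aromatic carbon. For the measured compounds named here, no single-point step between measured compounds is available, so the expected step from compound 2 to compound 3 is a 4.1-fold higher number from compound 2 to compound 3 (0.61 log units; beyond the scatter), a loss of potency somewhat beyond the scatter. Compound 3 is therefore expected to give about 1500 nM, between 400 nM and 8000 nM.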

Compound 3, half-maximal inhibitory concentration: 28700 nM
Compound 3: the middle estimate sits 19-fold (1.28 log units) below what was measured; measured number outside the range, above it.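

In this assay, 4-methoxyphenyl in place of 3-hydroxyphenyl, on the aromatic carbon next to the ring nitrogen, gives a 78-fold higher number from compound 2 to compound 3 (1.89 log units; beyond the scatter) and is the first change in one place among these compounds. It shows that the result in this assay depends strongly on the group at this position, which compound 1 and compound 2 could not show. Nothing shown here accounts for the size of this step.

From the compounds shown here alone, the change moves the oxygen on the ring, adds a methyl group to it and removes the hydrogen-bond donor all at once, so the contribution of each stays open. Neither 3-methoxyphenyl nor 3-aminophenyl is among the compounds shown at this position.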